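The source may report more compounds than this note shows. Statements on the series, on what has been measured and on what is new or still open speak of the compounds shown alone.

Measured compounds in an assay on a cell-free system (plasma) for inhibition of Dipeptidyl peptidase 4 (Rattus norvegicus), read by fluorescence; a lower number here means a stronger inhibitor, a higher number a weaker inhibitor:
- compound 1, `CN(Cc1ccc(C#N)cc1)[C@@H]1CN[C@H](C(=O)N2CCSC2)C1`, gives 13.6 nM
- compound 2, `CC(C)N(Cc1ccc(C#N)cc1)[C@@H]1CN[C@H](C(=O)N2CCSC2)C1`, gives 12.5 nM

Compound 2 carries the lower of the two numbers in this assay, but the gap to compound 1 is small: a 1.1-fold lower number from compound 1 to compound 2 (0.04 log units; within the scatter), a step that stays within the scatter. Both compounds share the same core and differ only in the group on the amine nitrogen.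

Compound 3, `CCCCN(Cc1ccc(C#N)cc1)[C@@H]1CN[C@H](C(=O)N2CCSC2)C1`, continues the same series of changes at that nitrogen: butyl in place of isopropyl on an amine nitrogen. Among the measured compounds shown here, the one measured step that bears on this is the one from methyl to isopropyl at the same place, which in this assay moved the number by no more than the scatter allows. A further enlargement of the alkyl group at this nitrogen is therefore expected to give no step beyond the scatter, a 1.0-fold higher number from compound 2 to compound 3 (0.02 log units; within the scatter). For compound 3 the expected value in this assay is 13 nM, with a range from 6 nM to 28 nM.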

Compound 3, half-maximal inhibitory concentration: 5 nM
Estimate against measurement, compound 3: 2.6-fold (0.41 log units) above; the whole stated range lies above it.
By their numbers in this assay, from the lowest: compound 3; then compounds 2 and 1 (each within the scatter of the next).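

In this assay the group on this amine nitrogen does affect the number: the change to butyl gives a step beyond the scatter (a 2.5-fold lower number from compound 2 to compound 3 (0.40 log units; beyond the scatter)), whereas the change from methyl to isopropyl gave none. The step from the methyl compound is of similar size (a 2.7-fold lower number from compound 1 to compound 3 (0.43 log units; beyond the scatter)), which sets compound 3 apart from compounds 1 and 2, themselves within the scatter of each other. No measurement at hand explains this step.

The compounds shown leave open whether the step follows chain length or the lack of branching, as butyl differs from isopropyl in both, and a straight propyl or a pentyl chain would bear on that. Also open, going by these compounds, is how a butyl chain ending in an amine or a carboxylic acid would compare with plain butyl at this nitrogen.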